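The compounds below may be only part of what the source reports. "The series", "measured", "known", "first", "only" and "open" are said of these compounds alone.

Working notes on the series. In a functional assay on HL-60 cells (Homo sapiens) for antiproliferative activity, with a stated time of 72 h (on this read-out lower numbers stand for stronger inhibition and higher numbers for weaker inhibition), compound 1 `OC[C@H]1O[C@@H](n2cnc3c(NCc4ccc(Br)cc4)ncnc32)[C@H](O)[C@@H]1O` gives 47400 nM and compound 2 `COc1cccc(CNc2ncnc3c2ncn3[C@@H]2O[C@H](CO)[C@@H](O)[C@H]2O)c1` gives 4900 nM. Compound 2 therefore holds the lower of the two numbers and is the stronger inhibitor of this pair. Compound 3 `COc1cc(CNc2ncnc3c2ncn3[C@@H]2O[C@H](CO)[C@@H](O)[C@H]2O)cc(OC)c1` keeps the shared core of compound 2 and changes only on the aromatic ring: methoxy in place of hydrogen on an aromatic carbon. In words, this is methoxy in place of hydrogen on an aromatic carbon, taking 3-methoxyphenyl to 3,5-dimethoxyphenyl.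

Among the compounds with values here, one measured step bears on this change, and only indirectly: a 9.7-fold lower number from compound 1 to compound 2 (0.99 log units; beyond the scatter). That modest step, beyond the scatter, replaces 4-bromophenyl with 3-methoxyphenyl on the same saturated chain carbon. Within the data shown here, it does not test a second methoxy, and no measured pair adds one, so the data give no direction. Among the measured compounds shown here, with that single step as the only guide, a smaller change is expected in this assay, most likely none beyond the scatter. The expected change is a 1.2-fold lower number from compound 2 to compound 3 (0.07 log units; within the scatter). Compound 3 is estimated at 4200 nM, with an expected range from 1300 nM to 14000 nM.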

Compound 3, half-maximal inhibitory concentration: 20200 nM
The estimate for compound 3 lay 4.8-fold (0.68 log units) below the measured number; measured number above the stated range.
By their numbers in this assay, from the lowest: compound 2; then compound 3; then compound 1.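

In this assay, methoxy in place of hydrogen on this aromatic carbon, meta to a methoxy group, has a measurable cost, with a 4.1-fold higher number from compound 2 to compound 3 (0.62 log units; beyond the scatter). Within the data shown here, this gives the second methoxy a direction that no earlier pair could show: taking 3-methoxyphenyl to 3,5-dimethoxyphenyl weakens inhibition, and only part of the advantage of 3-methoxyphenyl over 4-bromophenyl remains, with a 2.3-fold lower number from compound 1 to compound 3 (0.37 log units; beyond the scatter). No measurement shown here accounts for the loss of inhibition on adding this methoxy.

The compounds shown leave open whether the higher number is particular to methoxy, as neither hydroxy nor an amine in place of hydrogen on the same aromatic carbon is among them. From the compounds shown here alone, it also remains open how much of the difference between the 4-bromophenyl and 3-methoxyphenyl compounds comes from the bromine and how much from the methoxy, and a 3-bromophenyl compound would help to separate the two.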